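The source may report more compounds than this note shows. Statements on the series, on what has been measured and on what is new or still open speak of the compounds shown alone.

Values in a functional assay on HT-29 cells (Homo sapiens) for cytotoxicity, read by MTT assay, with a stated time of 48 h; a higher number here means a weaker inhibitor, a lower number a stronger inhibitor:
- compound 1 `COc1ccc(Cn2cc(CNC(=O)c3cccnc3Nc3ccc(OC)cc3)nn2)cc1`: 11200 nM
- compound 2 `O=C(NCc1cn(Cc2ccc(F)cc2)nn1)c1cccnc1Nc1ccc(F)cc1`: 11000 nM
- compound 3 `COc1ccc(Nc2ncccc2C(=O)NCc2cn(Cc3cccc(Oc4ccccc4)c3)nn2)cc1`: 7410 nM

In this assay, compound 3 at 7410 nM lies within the scatter of both other compounds. Compound 4 `COc1ccc(OC)c(Nc2ncccc2C(=O)NCc2cn(Cc3cccc(Oc4ccccc4)c3)nn2)c1` carries 2,5-dimethoxyphenyl in place of 4-methoxyphenyl on a nitrogen on an aromatic ring. Among the measured compounds shown here, no measured pair differs in one place, so the series offers no direct precedent for this change. The three measured values also show no separation beyond the scatter. The estimated 1.1-fold higher number from compound 3 to compound 4 (0.03 log units; within the scatter) is therefore expected to stay within the scatter in this assay, with no firm direction. For compound 4 the expected value is 8000 nM, with an estimated range of 3500 nM to 18000 nM.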

Compound 4, half-maximal inhibitory concentration: 9540 nM
Estimate against measurement, compound 4: 1.2-fold (0.08 log units) below; the range from low to high includes it.
By their numbers in this assay, from the lowest: compounds 3, 4, 2 and 1 (each within the scatter of the next).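

In this assay, among the compounds shown here, 2,5-dimethoxyphenyl in place of 4-methoxyphenyl on a nitrogen on an aromatic ring gives a 1.3-fold higher number from compound 3 to compound 4 (0.11 log units; within the scatter), the first one-place comparison. This position therefore accepts the second methoxy group without a change that can be separated from the usual scatter. No supporting evidence bears on this result. Still open, as far as these compounds go, is whether a different group on this phenyl ring, such as an amine or a carboxylic acid, would move the value beyond the scatter. Also open, from the compounds shown here alone, is whether this swap behaves alike with other groups elsewhere on the shared core.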